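The compounds below may be only part of what the source reports. "The series", "measured", "known", "first", "only" and "open" are said of these compounds alone.

Compound 1 `CC1(C)N=C(N)N=C(N)N1c1ccc(OCc2ccccc2S(=O)(=O)F)c(Cl)c1` is the reference of this set. In an assay on isolated protein for inhibition of Dihydrofolate reductase (Mus musculus) (on this read-out higher numbers stand for higher potency (the scale is a negative logarithm) and lower numbers for lower potency), compound 1 gives 7.43. Compound 2 `CC1(C)N=C(N)N=C(N)N1c1ccc(OCCCNC(=O)Nc2cccc(S(=O)(=O)F)c2)cc1` gives 7.32 in this assay, and compound 3 `CC1(C)N=C(N)N=C(N)N1c1ccc(OCCCNC(=O)Nc2cccc(S(=O)(=O)F)c2)c(Cl)c1` gives 7.28. The difference between the core of compound 1 and the core of compound 2 is not broken down here. Compound 2 and compound 3 differ by chloro in place of hydrogen on an aromatic carbon, and that change made a number 0.04 log units lower from compound 2 to compound 3 (within the scatter). The unmeasured compound 4 `CC1(C)N=C(N)N=C(N)N1c1ccc(OCc2cc(Cl)ccc2S(=O)(=O)F)c(Cl)c1` differs from compound 1 by chloro in place of hydrogen on an aromatic carbon, the same kind of change, though here the place is meta to a large group and para to a fluorosulfonyl group rather than ortho to a large group and meta to a large group. The author expects a step of about a number 0.03 log units lower from compound 1 to compound 4 (within the scatter) from compound 1 to compound 4, because the same kind of change gave a number 0.04 log units lower from compound 2 to compound 3 (within the scatter). For compound 4 an estimate of 7.4 is therefore expected, within 7 to 7.8.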

Compound 4, logarithm of the reciprocal of the active concentration, log(1/C): 7.27
The estimate for compound 4 lay 0.13 log units above the measured number, and the stated range covers the measured number.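

In this assay, chloro in place of hydrogen on an aromatic carbon gave a number 0.16 log units lower from compound 1 to compound 4 (within the scatter), and set beside the earlier case the two steps agree: the same change on two cores in this assay, a number 0.04 log units lower (within the scatter) from compound 2 to compound 3 and a number 0.16 log units lower (within the scatter) from compound 1 to compound 4, 0.12 log units apart, within the scatter of two such steps. On these two cores, then, the change carried over, and both steps stayed within the scatter. This is a single pair of steps at different places, so it does not show that the change would behave the same way at other places or on other cores.

The compounds shown leave open what a methyl, a methoxy group or an amine would do at the place para to a fluorosulfonyl group. They also leave open whether the number would hold with a carboxylic acid in place of the fluorosulfonyl group.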